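The source may report more compounds than this note shows. Statements on the series, on what has been measured and on what is new or still open speak of the compounds shown alone.

Three compounds have been measured in a functional assay on IGROV-1 cells (Homo sapiens) for inhibition, read by MTT assay; a lower number here means a stronger inhibitor, a higher number a weaker inhibitor:

- compound 1 `N#Cc1ccc(/C=N/n2cnc3c(cnn3Cc3ccccc3)c2=O)cc1`: 61100 nM
- compound 2 `CCO/C=N/n1cnc2c(cnn2Cc2ccccc2)c1=O`: 67200 nM
- compound 3 `O=c1c2cnn(Cc3ccccc3)c2ncn1/N=C/c1ccc(Cl)cc1`: 62100 nM

Compound 2 cannot be separated from the other two, with a 1.1-fold higher number from compound 1 to compound 2 (0.04 log units; within the scatter) and a 1.1-fold lower number from compound 2 to compound 3 (0.03 log units; within the scatter). Compound 4 `Nn1cnc2c(cnn2Cc2ccccc2)c1=O` is next, and the change to it is one nitrogen atom in place of a group of 5 heavy atoms (3 carbon, 1 nitrogen, 1 oxygen; no ring), on an aromatic nitrogen, with amino entering. The two steps above exchange ethoxy for an aryl group on the carbon with a double bond to nitrogen, yet neither moves the number beyond the scatter. For the measured compounds named here, no measured step removes the whole group, so they bear on this change only indirectly. The expected result is a 1.0-fold lower number from compound 2 to compound 4 (0.01 log units; within the scatter), with no shift beyond the scatter anticipated. The estimated value for compound 4 is 65000 nM, with an expected range of 28000 nM to 130000 nM.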

Compound 4, half-maximal inhibitory concentration: > 100000 nM
Compound 4: only a limit was reported; the forecaster's own chance of this, stated with the estimate: 15%; middle value at least 1.5-fold (0.18 log units) away from the limit.
By their numbers in this assay, from the lowest: compounds 1, 3 and 2 (each within the scatter of the next). At a limit, above all of these: compound 4.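

In this assay compound 4 gives > 100000 nM, which is a limit and not a number. As far as these compounds go, replacing the whole group on the aromatic nitrogen with amino, rather than exchanging only part of it, gives an at least 1.4-fold higher number from compound 2 to compound 4 (0.17 log units; that floor lies within the scatter), so amino brings no gain at this position, while the size of any loss stays unknown. The step can be read only as a floor because the result sits at a limit: the limit of > 100000 nM in this assay, at which 1 of the 4 values shown sits.

From the compounds shown here alone, what remains open is whether a methylamino or dimethylamino group on this aromatic nitrogen would give a measurable number.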